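The source may report more compounds than this note shows. Statements on the series, on what has been measured and on what is new or still open speak of the compounds shown alone.

Compound 1 `CCC(COc1cccc(Cl)c1)OC(=O)NCc1ccccc1` gives > 100000 nM in an assay for inhibition of zeta-carotene desaturase, chloroplastic/chromoplastic (Capsicum annuum), using a Dixon plot, with a stated time of 8 h (on this read-out higher numbers stand for weaker inhibition and lower numbers for stronger inhibition), a limit rather than a number.
Compound 2 `CCC(COc1cccc(Cl)c1)OC(=O)NC(C)c1ccccc1` gives > 100000 nM in this assay, again a limit.
Compound 3 `CCC(COc1cccc(Cl)c1)OC(=O)N[C@H](C)c1ccccc1` gives > 100000 nM in this assay, also a limit.

Compound 3 therefore stands at the same limit as the other two, with no measured number of its own. The steps a step that the two limits leave unreadable from compound 1 to compound 2, a step that the two limits leave unreadable from compound 1 to compound 3 and a step that the two limits leave unreadable from compound 2 to compound 3 are all unreadable because of the limit of > 100000 nM in this assay, at which 3 of the 3 values shown sit. Compound 4 `CCC(COc1cccc(Cl)c1)OC(=O)N[C@@H](C)c1ccccc1` differs from compound 3 in that (the two compounds have the same atoms and bonds; at least one stereo element is drawn with a configuration in one of them and without one in the other: 1 of 2 stereo elements differ; a stereocentre at a saturated chain carbon is drawn R in compound 3 and S in compound 4). Going by the values given here, compound 2 is drawn without a configuration at that centre, and the fact that one of compounds 2 and 3 is drawn with a defined configuration and the other without, at the place where they differ is the only evidence that touches this change, yet compound 2 also sits at the limit, so no readable step exists. Compound 4 is expected to give 100000 nM, with a range from 30000 nM to 300000 nM, and most likely only a limit will be reported. The step from compound 3 to compound 4 is expected to be a number no higher from compound 3 to compound 4 (the limit leaves the size open), nothing beyond the scatter.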

Compound 4, half-maximal inhibitory concentration: > 100000 nM
Compound 4 gave a limit, no number; the forecaster's own chance of this, stated with the estimate: 85%; the middle value lies on the limit itself.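

In this assay compound 4 gives > 100000 nM as a limit and not a number, so its steps from compound 1, compound 2 and compound 3 cannot be read. The compounds shown leave open whether the added methyl or either configuration at that carbon changes inhibition at all.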